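Terminal group swap on a long-chain lactone

The compounds below may be only part of what the source reports. "The series", "measured", "known", "first", "only" and "open" are said of these compounds alone.

Compound 1, `CC(C)(C)C(=O)OCC1(CO)C/C(=C\CCCCCCCCCCCO)C(=O)O1`: > 10 ug/mL
Compound 2, `COCCCCCCCCCCCCCCC/C=C1\CC(CO)(COC(=O)C(C)(C)C)OC1=O`: 5.45 ug/mL
Compound 3, `CC(=O)NCCCCCCCCCCCCCCC/C=C1\CC(CO)(COC(=O)C(C)(C)C)OC1=O`: > 10 ug/mL

Among the measured compounds shown here, compound 2 stands as the only measurement that is a number: in a functional assay on Hs-578T cells (Homo sapiens) for antiproliferative activity (a lower number here means a stronger inhibitor of growth, a higher number a weaker inhibitor of growth), compound 2 gives 5.45 ug/mL. Compound 1 and compound 3 each sit at the limit of > 10 ug/mL in this assay, at which 2 of the 3 values shown sit. Both measured steps change the same remote end of the chain: an at least 1.8-fold lower number from compound 1 to compound 2 (0.26 log units; that floor lies within the scatter), and an at least 1.8-fold higher number from compound 2 to compound 3 (0.26 log units; that floor lies within the scatter). Compound 4, `CC(C)(C)C(=O)OCC1(CO)C/C(=C\CCCCCCCCCCCCCCC=O)C(=O)O1`, carries a change at that same place: formyl in place of methoxymethyl on a saturated chain carbon, ten or more bonds along the chain from a double-bonded chain carbon. The two neighbouring steps point in opposite directions and each reaches only a limit, so their size cannot be pinned down. The account therefore expects only a modest step, a 1.5-fold higher number from compound 2 to compound 4 (0.17 log units; within the scatter), with a real chance that compound 4 itself ends at a limit. Compound 4 is estimated at 8 ug/mL, between 3 ug/mL and 25 ug/mL.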

Compound 4, concentration for 50% growth inhibition: > 10 ug/mL
Compound 4: no number, only a limit; the forecaster's own chance of this, stated with the estimate: 45%; middle value at least 1.2-fold (0.09 log units) from the limit.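

In this assay compound 4 gives > 10 ug/mL, which is a limit and not a number. Formyl in place of methoxymethyl at this remote chain end gives an at least 1.8-fold higher number from compound 2 to compound 4 (0.26 log units; that floor lies within the scatter), while the steps from compound 1 and compound 3 to compound 4 join two limits and cannot be read. Compound 2 remains the only compound with a number, and a third terminal group now ends at the same limit: the limit of > 10 ug/mL in this assay, at which 3 of the 4 values shown sit.

As far as these compounds go, how far compound 1, compound 3 and compound 4 truly lie from compound 2 stays open. So does whether an amine or a carboxylic acid at this chain end would give a number.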